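Chloro added to the benzyl group of compound 3

The source may report more compounds than this note shows. Statements on the series, on what has been measured and on what is new or still open speak of the compounds shown alone.

Compound 1 `CC(C)(COC(=O)[C@@H](N)c1ccccc1)COC1(c2ccc(Cl)cc2)c2ccccc2C(=O)N1Cc1ccccc1` gives 44000 nM
Compound 2 `O=C1c2ccccc2C(OCCCO)(c2ccc(Cl)cc2)N1Cc1ccccc1` gives 90000 nM
Compound 3 `CC(C)(CO)COC1(c2ccc(Cl)cc2)c2ccccc2C(=O)N1Cc1ccccc1` gives 82000 nM

In a functional assay on HCT-116 cells (Homo sapiens) for inhibition, read by fluorescence, with a stated time of 48 h (a lower number here means a stronger inhibitor of growth, a higher number a weaker inhibitor of growth), compound 3 stands within the scatter of both other compounds. Two measured steps reach it (a 1.9-fold higher number from compound 1 to compound 3 (0.27 log units; within the scatter)) and (a 1.1-fold lower number from compound 2 to compound 3 (0.04 log units; within the scatter)) and neither alters the benzyl group. Compound 4 `CC(C)(CO)COC1(c2ccc(Cl)cc2)c2ccccc2C(=O)N1Cc1ccc(Cl)cc1` has chloro in place of hydrogen on an aromatic carbon and so turns benzyl to 4-chlorobenzyl. No measured step sizes this change, so no shift beyond the scatter is expected in this assay for now. The expected step is small (a 1.5-fold lower number from compound 3 to compound 4 (0.17 log units; within the scatter)). Compound 4 is estimated at 55000 nM with an expected range (22000 nM to 110000 nM).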

Compound 4, concentration for 50% growth inhibition: 65000 nM
The estimate for compound 4 lay 1.2-fold (0.07 log units) below the measured number; the range from low to high includes it.
By their numbers in this assay, from the lowest: compounds 1, 4, 3 and 2 (each within the scatter of the next, the first and the last beyond it).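

Turning benzyl to 4-chlorobenzyl gives the first measured step on this ring: in this assay, chloro in place of hydrogen gives a 1.3-fold lower number from compound 3 to compound 4 (0.10 log units; within the scatter). The earlier steps shown here changed only the chain on the oxygen, whereas this one shows that a single chlorine on the benzyl group leaves growth inhibition within the scatter. No available evidence bears on this result. As far as these compounds go, whether an amine, a carboxylic acid or a longer chain at this place would move the number beyond the scatter remains open. Also open, from the compounds shown here alone, is whether chloro here would behave the same alongside the (amino(phenyl)methyl)carbonyl group of compound 1.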